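Cytotoxicity in lung cells: a pyridinylmethylamino variant

The compounds below may be only part of what the source reports. "The series", "measured", "known", "first", "only" and "open" are said of these compounds alone.

Measured so far:
Compound 1, `CN(C)c1ccc(NC(=O)c2cc(Cl)ccc2O)c(Cl)c1`: 85100 nM
Compound 2, `O=C(Nc1ccc(NCc2cc(C(F)(F)F)cc(C(F)(F)F)c2)cc1Cl)c1cc(Cl)ccc1O`: 92800 nM

Both compounds were tested in an ADME assay on A549 cells (Homo sapiens) for cytotoxicity, read by resazurin assay, with a stated time of 48 h; a lower number here means that less compound is tolerated, a higher number that more compound is tolerated. Compound 1 gives the lower of the two numbers, but compound 2 lies within the scatter of it, so the two compounds cannot be told apart on this read-out.

Compound 3, `O=C(Nc1ccc(NCc2ccncc2)cc1Cl)c1cc(Cl)ccc1O`, has not yet been measured in this assay. It differs from compound 1 in one place: ((pyridin-4-yl)methyl)amino in place of dimethylamino on an aromatic carbon. Among the compounds with values here, no step between two measured compounds covers this change, so there is no direct precedent; the only guide is that compound 1 and compound 2, which carry different substituents at the same position of the shared core, give half-maximal cytotoxic concentrations within the scatter of each other.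

On that basis, compound 3 is expected to show no step beyond the scatter, a 1.1-fold lower number from compound 1 to compound 3 (0.03 log units; within the scatter), with an estimate of 80000 nM and a likely range from 30000 nM to 200000 nM.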

Compound 3, half-maximal cytotoxic concentration: 65300 nM
For compound 3 the middle estimate is 1.2-fold (0.09 log units) above the measured one; the range from low to high includes it.
By their numbers in this assay, from the lowest: compounds 3, 1 and 2 (each within the scatter of the next).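

In this assay the change to ((pyridin-4-yl)methyl)amino from dimethylamino on this aromatic carbon gives a 1.3-fold lower number from compound 1 to compound 3 (0.12 log units; within the scatter) and so stays within the scatter, even though it brings in a six-membered aromatic ring with a hetero atom and a hydrogen-bond donor. The earlier pair had not shown a ring with a hetero atom at this position, and compound 3 now joins compounds 1 and 2, each within the scatter of the next, so three different substituents here cannot be told apart on this read-out. Nothing measured here offers an explanation for this result.

As far as these compounds go, what remains open is whether a carboxylic acid or a primary amine at this position would produce a step beyond the scatter. From the compounds shown here alone, whether the same holds when the chloro group on this ring is replaced by a methoxy group also remains open.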